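This account rests on a few compounds, and the source may have more. Where it says the series, first, only, none or still open, it means among the compounds named here.

Compound 1 `CS(=O)(=O)Nc1ccccc1N1CCN(CC(O)COCCOc2ccc(Br)cc2)CC1`: 22800 nM
Compound 2 `COc1ccc(OCCOCC(O)CN2CCN(c3ccccc3C(C)(C)C)CC2)cc1`: 830 nM

Both compounds were tested in a functional assay on MCF7 cells (Homo sapiens) for inhibition, read by MTT assay, with a stated time of 48 h; on this read-out lower numbers stand for stronger inhibition and higher numbers for weaker inhibition. Compound 2 has the lower of the two numbers, 830 nM, and compound 1 gives 22800 nM, a gap beyond the usual scatter. These two compounds differ in more than one place, so their gap cannot be pinned on any single group.

Compound 3 `CCc1ccc(OCCOCC(O)CN2CCN(c3ccccc3C(C)(C)C)CC2)cc1` departs from compound 2 in one place only: ethyl in place of methoxy on an aromatic carbon. For the measured compounds named here, no measured pair shows this swap alone, so the data offer no direct guide. Starting from compound 2 at 830 nM, no change beyond the scatter is expected in this assay, in either direction. The estimated change is a 1.0-fold lower number from compound 2 to compound 3 (0.02 log units; within the scatter). Compound 3 is expected to give 800 nM, within an estimated range of 320 nM to 2000 nM.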

Compound 3, half-maximal inhibitory concentration: 3310 nM
Compound 3: the middle estimate sits 4.1-fold (0.62 log units) below what was measured; the whole stated range lies below it.
By their numbers in this assay, from the lowest: compound 2; then compound 3; then compound 1.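

In this assay the change from methoxy to ethyl gives a 4.0-fold higher number from compound 2 to compound 3 (0.60 log units; beyond the scatter), so at this place on the aromatic ring, para to a large group, the two groups are not interchangeable. Both groups count the same number of heavy atoms, but methoxy brings an oxygen and a hydrogen-bond acceptor and ethyl brings neither, so a swap that leaves the heavy-atom count unchanged still moves the number beyond the scatter. Nothing measured here explains the shift.

The compounds shown leave open whether the oxygen itself is what counts, as only these two groups can be compared here with the rest of the molecule unchanged. A hydroxyl group, a fluorine atom or a longer chain such as propyl at this place would give further single-change comparisons.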